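Swapping sec-butyl for a tert-butyl ester chain

The source may report more compounds than this note shows. Statements on the series, on what has been measured and on what is new or still open speak of the compounds shown alone.

In a functional assay on MCF7 cells (Homo sapiens) for inhibition, read by MTT assay, with a stated time of 72 h (a higher number here means a weaker inhibitor, a lower number a stronger inhibitor), compound 1 `C[C@H](NC(=O)c1cc(Cl)ccc1OCCN)C(=O)Nc1ccc([N+](=O)[O-])cc1Cl` gives > 10000 nM, which is a limit. Compound 2 `CC[C@@H](C)[C@H](NC(=O)c1cc(Cl)ccc1OCCN)C(=O)Nc1ccc([N+](=O)[O-])cc1Cl` gives > 10000 nM, also a limit and not a number. The evidence so far is the limit of > 10000 nM in this assay, at which 2 of the 2 values shown sit. Compound 3 `CC(C)(C)OC(=O)CC[C@H](NC(=O)c1cc(Cl)ccc1OCCN)C(=O)Nc1ccc([N+](=O)[O-])cc1Cl` carries 2-(tert-butoxycarbonyl)ethyl in place of sec-butyl on a saturated chain carbon bound to an amide-type nitrogen and a carbonyl carbon. Going by the values given here, the only measured step bearing on this change is a step that the two limits leave unreadable from compound 1 to compound 2, so it gives no size to carry over. In this assay no shift beyond the scatter is expected, and the estimated step is a step that the limit leaves unreadable from compound 2 to compound 3. Compound 3 is estimated at 12000 nM, with an expected range of 4000 nM to 30000 nM.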

Compound 3, half-maximal inhibitory concentration: 3080 nM
Compound 3: middle estimate off by 3.9-fold (0.59 log units), on the high side; the whole stated range lies above it.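

In this assay, this position now gives a readable response: an at least 3.2-fold lower number from compound 2 to compound 3 (0.51 log units; beyond the scatter) with 2-(tert-butoxycarbonyl)ethyl in place of sec-butyl, and an at least 3.2-fold lower number from compound 1 to compound 3 (0.51 log units; beyond the scatter) against the methyl side chain. The side chain on this carbon can therefore move the read-out beyond the scatter, although both sizes are lower bounds. The step between the two earlier compounds cannot be read.

The compounds shown do not separate the contribution of the tert-butyl ester from that of chain length. A free carboxylic acid or a plain longer alkyl chain on this carbon would distinguish the two.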